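Shortening the Chain of Compound 2

A few compounds are considered here, and "the series" means these few. Any claim that something is new, unique, unknown or untested is made for them only; others in the source may bear on it.

Compound 1 `CCC/C(=N\C#N)N(C)Cc1ccc(Cl)nc1`: 1.55
Compound 2 `CCCCC/C(=N\C#N)N(C)Cc1ccc(Cl)nc1`: 2.3

Measured by a physicochemical assay for lipophilicity, read by HPLC, using the shake flask method (a lower number here means a more polar compound, a higher number a more lipophilic compound), compound 2 holds the higher of the two numbers, at 2.3, and compound 1 lies below it, beyond the scatter. The next compound, compound 3 `CC/C(=N\C#N)N(C)Cc1ccc(Cl)nc1`, differs from compound 2 as follows: hydrogen in place of propyl on a saturated chain carbon, two bonds along the chain from a carbon with a double bond to nitrogen. In words, this is hydrogen in place of propyl on a saturated chain carbon, two bonds along the chain from a carbon with a double bond to nitrogen.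

Among the compounds with values here, only one measured step bears on this change: a number 0.75 log units higher from compound 1 to compound 2 (beyond the scatter). That modest step came with ethyl in place of hydrogen on a saturated chain carbon, three bonds along the chain from a carbon with a double bond to nitrogen. The new change removes propyl instead, so the number in this assay is expected to move the opposite way, and by somewhat more than in that measured step. The estimated step is a number 1.10 log units lower from compound 2 to compound 3 (beyond the scatter), expected to lie beyond the scatter. In this assay compound 3 is expected at 1.2, with an estimated range of 0.9 to 1.5.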

Compound 3, partition coefficient: 1.12
For compound 3 the middle estimate is 0.08 log units above the measured one, within the range that was stated.
By their numbers in this assay, from the lowest: compound 3; then compound 1; then compound 2.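

Until now, the chain had been seen only growing, through a single step in one direction. The new compound shows the reverse change at this position: in this assay, replacing propyl with hydrogen gives a number 1.18 log units lower from compound 2 to compound 3 (beyond the scatter) and is printed as large, while replacing methyl with hydrogen gives a number 0.43 log units lower from compound 1 to compound 3 (beyond the scatter) and is printed as modest, so the drop is seen for both a small and a larger group removed from the same carbon. With a number 0.75 log units higher from compound 1 to compound 2 (beyond the scatter) alongside them, the three compounds fall in the same order as the length of the chain, from the ethyl of compound 3 to the pentyl of compound 2, and none of them goes against that order, although nothing given here explains why the number follows the chain in this way.

From the compounds shown here alone, the three compounds cover only a short stretch of unbranched chains on the shared core, so it remains open whether a longer chain such as octyl would carry the same trend further. Going by these compounds, it is equally open how the number would respond to a branched chain, or to a chain ending in an amine or a carboxylic acid, at this same position.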